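Aryl substituent variation on the shared core: methoxy analogue

The source may hold more compounds than are shown below. What is called first, only, known or untested is meant among the compounds shown, and "the series" means these compounds.

Measured so far, in a functional assay on A549 cells (Homo sapiens) for antiproliferative activity, read by XTT assay, with a stated time of 24 h; a lower number here means a stronger inhibitor, a higher number a weaker inhibitor:
- compound 1, `CS(=O)(=O)c1ccc(-c2csc(N3N=C(c4ccc(Cl)s4)CC3c3ccc(F)cc3)n2)cc1`: compound 1 gives > 500 ug/mL
- compound 2, `N#Cc1ccc(-c2csc(N3N=C(c4ccc(Cl)s4)CC3c3ccc(F)cc3)n2)cc1`: compound 2 gives > 500 ug/mL
- compound 3, `Cc1ccc(-c2csc(N3N=C(c4ccc(Cl)s4)CC3c3ccc(F)cc3)n2)cc1`: compound 3 gives > 500 ug/mL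

Each of these three values is a limit of the assay, not a number. Compound 3 therefore stands at that limit, and the two other values shown stand at the same limit, so compound 3 cannot be ranked against them in this assay. The three measured steps, a step that the two limits leave unreadable from compound 1 to compound 2, a step that the two limits leave unreadable from compound 1 to compound 3 and a step that the two limits leave unreadable from compound 2 to compound 3, are each unreadable in size and direction, as the evidence states: the limit of > 500 ug/mL in this assay, at which 3 of the 3 values shown sit.

The next compound is compound 4, `COc1ccc(-c2csc(N3N=C(c4ccc(Cl)s4)CC3c3ccc(F)cc3)n2)cc1`. It differs from compound 3 in one place: methoxy in place of methyl on an aromatic carbon. Within the data shown here, the steps that bear on it are the three unreadable ones above; none of them gives a size, so no step beyond the scatter can be read from them in this assay, and the most that the measured values suggest is that a fourth change on the same aromatic carbon also leaves the value at the limit.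

On that basis compound 4 is expected to give about 600 ug/mL in this assay, with a range from 250 ug/mL to 2000 ug/mL. The estimated step from compound 3 is a step that the limit leaves unreadable from compound 3 to compound 4, and it is expected to be none beyond the scatter.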

Compound 4, half-maximal inhibitory concentration: > 500 ug/mL
Compound 4: no number, only a limit; the forecaster's own chance of this, stated with the estimate: 85%; the middle value is on the limit's open side.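

In this assay compound 4 gives > 500 ug/mL, which is a limit and not a number. No new step can be read between compound 4 and compound 1, compound 2 or compound 3, which all sit at the same limit: the limit of > 500 ug/mL in this assay, at which 4 of the 4 values shown sit.

The compounds shown leave open how these four compounds rank in this assay, and whether any aryl substituent on the shared core gives a measurable value there.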